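Tail aryl change from compound 1 toward a smaller halogenated ring

The compounds below may be only part of what the source reports. "The series", "measured", "known", "first", "only" and "open" are said of these compounds alone.

Compound 1, `O=C(O)CC(O)(CSCCCCCCc1cccc(Cl)c1Cl)C(=O)O`, is the point of reference in this set. In an assay on isolated protein for inhibition of ATP-citrate synthase (Rattus norvegicus) (on this read-out higher numbers stand for weaker inhibition and lower numbers for stronger inhibition), compound 1 gives 7300 nM, the lowest of the three numbers recorded. Compound 2, `O=C(O)CC(O)(CSCCCCCOc1ccc(Cl)cc1Cl)C(=O)O`, gives 67000 nM in this assay, and compound 3, `O=C(O)CC(O)(CSCCCCNS(=O)(=O)c1ccc(Cl)cc1Cl)C(=O)O`, gives 175000 nM in this assay; both of these lie beyond the scatter from compound 1, so compound 1 stands clearly as the tightest binder among the measured compounds. No pair among these three differs in a single place, so no isolated step can be read from them.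

Compound 4, `O=C(O)CC(O)(CSCCCCCCc1ccc(F)cc1)C(=O)O`, is yet to be measured. It differs from compound 1 in one place: 4-fluorophenyl in place of 2,3-dichlorophenyl on a saturated chain carbon, six bonds along the chain from a sulfur. The chain and the shared core are unchanged.

Expectation: the measured compounds offer no direct precedent for this swap. A modest loss is expected, with the step from compound 1 to compound 4 estimated at a 2.7-fold higher number from compound 1 to compound 4 (0.44 log units; beyond the scatter) in this assay, somewhat beyond the scatter. Compound 4 is therefore expected to give about 20000 nM in this assay, within a range of 7000 nM to 60000 nM.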

Compound 4, inhibition constant: 120000 nM
For compound 4 the middle estimate is 6.0-fold (0.78 log units) below the measured one; the whole stated range lies below it.
By their numbers in this assay, from the lowest: compound 1; then compounds 2, 4 and 3 (each within the scatter of the next, the first and the last beyond it).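

With the chain and the shared core held fixed, the aryl group at this position has a strong effect on the read-out in this assay: 4-fluorophenyl in place of 2,3-dichlorophenyl gives a 16-fold higher number from compound 1 to compound 4 (1.22 log units; beyond the scatter). Within the data shown here, this is the first step that isolates a single place, and the earlier compounds could not show that the ring substitution alone, with no change to the chain, moves the number this far. Nothing measured here accounts for the size of this step.

The change replaces the type of halogen, the number of halogens and their ring positions together, so the contribution of each remains unresolved; phenyl without a halogen, 4-chlorophenyl and 2,3-difluorophenyl, each on a saturated chain carbon, six bonds along the chain from a sulfur, would separate these contributions. Also open, on these data alone, is whether 2,3-dichlorophenyl keeps its advantage over 4-fluorophenyl on a longer chain, since the step is known for only one chain.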